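This account rests on a few compounds, and the source may have more. Where it says the series, first, only, none or still open, it means among the compounds named here.

Measured compounds in a functional assay on A549 cells (Homo sapiens) for cytotoxicity, read by MTT assay, with a stated time of 48 h; a lower number here means a stronger inhibitor, a higher number a weaker inhibitor:
Compound 1 `Cc1cccc(Cn2cc(COc3ccc4c(=O)ccoc4c3)nn2)c1` gives 20300 nM.
Compound 2 `O=c1ccoc2cc(OCc3cn(Cc4cccc(F)c4)nn3)ccc12` returns only a limit of the assay, > 100000 nM.
Compound 3 `O=c1ccoc2cc(OCc3cn(Cc4cccc([N+](=O)[O-])c4)nn3)ccc12` gives 9450 nM.

Compound 1 holds the higher of the two numbers; its nearest neighbour is compound 3, reached by a 2.1-fold lower number from compound 1 to compound 3 (0.33 log units; beyond the scatter). The other measured change from compound 1, an at least 4.9-fold higher number from compound 1 to compound 2 (0.69 log units; beyond the scatter), runs the opposite way and ends at the limit (the limit of > 100000 nM in this assay, at which 1 of the 3 values shown sits). Between the two substituted compounds the gap is an at least 10-fold lower number from compound 2 to compound 3 (1.02 log units; beyond the scatter).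

Compound 4 `O=c1ccoc2cc(OCc3cn(Cc4ccc(Br)cc4)nn3)ccc12` is the next step from compound 1: 4-bromophenyl in place of 3-methylphenyl on a saturated chain carbon bound to an aromatic nitrogen. None of the three measured steps puts a bromine on the ring, and each of them swaps one group for another at one place, whereas the step to compound 4 also changes the group's place on the ring. Among the compounds with values here, no measured step therefore bears on it directly. The closest in kind is an at least 4.9-fold higher number from compound 1 to compound 2 (0.69 log units; beyond the scatter), where a halogen replaced the methyl and the number rose past the limit; the nitro group, by contrast, lowered it. Within the data shown here, with no direct precedent, the expectation is a step in this assay of at most modest size, a weaker number being the likelier direction in line with an at least 4.9-fold higher number from compound 1 to compound 2 (0.69 log units; beyond the scatter), but a result within the scatter is plausible. Compound 4 is estimated at 30000 nM, ranging from 10000 nM to 100000 nM. This estimate amounts to a 1.5-fold higher number from compound 1 to compound 4 (0.17 log units; within the scatter).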

Compound 4, half-maximal inhibitory concentration: > 100000 nM
Compound 4: no number, only a limit; the forecaster's own chance of this, stated with the estimate: 20%; middle value at least 3.3-fold (0.52 log units) away from the limit.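

In this assay, 4-bromobenzyl in place of 3-methylbenzyl gives an at least 4.9-fold higher number from compound 1 to compound 4 (0.69 log units; beyond the scatter), and the gap to the nitro compound is wider, with an at least 10-fold higher number from compound 3 to compound 4 (1.02 log units; beyond the scatter). A halogen on this ring has now ended at the limit twice, in compound 2 and compound 4, even though the two compounds differ in both the halogen and its place on the ring, while compound 1 and compound 3 are the two that go against any general loss at this position and still give numbers. Readable values in this small set now rest on only those two compounds, and the rest carry no number: the limit of > 100000 nM in this assay, at which 2 of the 4 values shown sit.

Within the data shown here, the step from compound 2 to compound 4 joins two limits and cannot be read, so the two halogens cannot be ranked, and the single step from compound 1 to compound 4 cannot separate the change of group from the change of ring place. As far as these compounds go, whether an amine or a carboxylic acid on this ring, or a longer chain in place of the benzyl group, would bring the number back under the limit stays open.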